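The source may hold more compounds than are shown below. What is called first, only, known or untested is meant among the compounds shown, and "the series" means these compounds.

Measured so far:
compound 1 `COc1cc2c(Oc3ccc(NC(=O)c4nn(-c5ccccc5C(F)(F)F)c(=O)cc4C)cc3F)ccnc2cc1OCCCN1CCC(C)CC1` — 160 nM
compound 2 `COc1ccc(-n2nc(C(=O)Nc3ccc(Oc4ccnc5cc(OCCCN6CCC(C)CC6)c(OC)cc45)c(F)c3)c(C)cc2=O)cc1` — 1100 nM

Both were tested in a functional assay on A549 cells (Homo sapiens) for inhibition, read by MTT assay, with a stated time of 72 h; a higher number here means a weaker inhibitor, a lower number a stronger inhibitor. For the measured compounds named here, compound 2 stands at the higher of the two numbers, with compound 1 as its only neighbour: the single step, a 6.9-fold higher number from compound 1 to compound 2 (0.84 log units; beyond the scatter), turns on the aryl group carried by the aromatic nitrogen, a 4-methoxyphenyl in place of a 2-(trifluoromethyl)phenyl.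

Compound 3 `COc1cc2c(Oc3ccc(NC(=O)c4nn(-c5ccc(Cl)cc5)c(=O)cc4C)cc3F)ccnc2cc1OCCCN1CCC(C)CC1` is not yet measured. It differs from compound 2 in one place: chloro in place of methoxy on an aromatic carbon, on an aromatic carbon of a six-membered aromatic ring of carbon only, para to a large group; cut one bond further out this reads 4-methoxyphenyl to 4-chlorophenyl.

Going by the values given here, no measured step swaps methoxy for chloro directly. Among the compounds with values here, the only step that bears on the question is a 6.9-fold higher number from compound 1 to compound 2 (0.84 log units; beyond the scatter), which shows that changing the group on this ring moves the number by a modest amount. On that basis compound 3 is expected to shift by a step of comparable or smaller size, more likely downward than upward, so for compound 3 the estimate is 500 nM in this assay, within 150 nM to 1600 nM, that is a 2.2-fold lower number from compound 2 to compound 3 (0.34 log units; beyond the scatter).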

Compound 3, half-maximal inhibitory concentration: 210 nM
Compound 3: middle estimate off by 2.4-fold (0.38 log units), on the high side, within the range that was stated.
By their numbers in this assay, from the lowest: compounds 1 and 3 (each within the scatter of the next); then compound 2.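

In this assay, chloro in place of methoxy on an aromatic carbon, para to a large group, gives a 5.2-fold lower number from compound 2 to compound 3 (0.72 log units; beyond the scatter), so the aryl group on the aromatic nitrogen matters here through the identity of this one substituent and not only through the change of aryl group seen earlier. The earlier step could not separate the loss of the 2-(trifluoromethyl)phenyl group from the presence of methoxy, but a 1.3-fold higher number from compound 1 to compound 3 (0.12 log units; within the scatter) now shows that a 4-chlorophenyl group and a 2-(trifluoromethyl)phenyl group cannot be told apart in this read-out, which leaves the higher number of compound 2 tied, among these three compounds, to the 4-methoxyphenyl group. Nothing among the data given accounts for this difference between chloro and methoxy.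

Going by these compounds, it remains open whether a fluoro, a methyl, a hydroxy group or an amine in that same place would sit with chloro or with methoxy, or whether an unsubstituted phenyl would sit with either. For the compounds shown here, with only three compounds in a single cell assay, it also remains open whether the methoxy-to-chloro step would hold with another group in place of the methylpiperidine-bearing chain.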